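This account rests on a few compounds, and the source may have more. Where it says the series, first, only, none or still open, it means among the compounds named here.

Measured compounds in an assay on mitochondria for inhibition of Amine oxidase [flavin-containing] A (Bos taurus); on this read-out higher numbers stand for weaker inhibition and lower numbers for stronger inhibition:
- compound 1 `Cc1ccc(C2=NN(C(N)=S)C(c3ccc(Cl)cc3)C2)cc1` gives 31 nM
- compound 2 `Cc1ccc(C2=NN(C(N)=S)[C@@H](c3ccc(Cl)cc3)C2)cc1` gives 13 nM
- compound 3 `Cc1ccc(C2=NN(C(N)=S)C(c3ccc(C)cc3)C2)cc1` gives 6 nM

Compound 3 stands at the lowest number of the three; compound 2 lies nearest to it, compound 1 furthest, both steps beyond the scatter. Of the two measured steps, a 5.2-fold lower number from compound 1 to compound 3 (0.71 log units; beyond the scatter) sits at the same saturated ring carbon as the change now considered, and a 2.4-fold lower number from compound 1 to compound 2 (0.38 log units; beyond the scatter) concerns only the configuration at that carbon, a point to which the fact that one of compounds 1 and 2 is drawn with a defined configuration and the other without, at the place where they differ relates.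

Compound 4 `Cc1ccc(C2=NN(C(N)=S)C(c3ccco3)C2)cc1` differs from compound 3 by furan-2-yl in place of 4-methylphenyl on a saturated ring carbon. Among the measured compounds shown here, the one step at this position exchanged a substituent on the aryl ring and was modest; the present change swaps the whole ring for a smaller heteroaromatic one, for which no measured step exists. The expectation is therefore cautious: a modest upward step in this assay, a 2.5-fold higher number from compound 3 to compound 4 (0.40 log units; beyond the scatter), with wide uncertainty. Compound 4 is estimated at 15 nM, within a range from 4 nM to 60 nM.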

Compound 4, inhibition constant: 4 nM
Beside the measured number, compound 4's estimate is 3.8-fold (0.57 log units) above it; the range from low to high includes it.
By their numbers in this assay, from the lowest: compounds 4 and 3 (each within the scatter of the next); then compound 2; then compound 1.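

In this assay, furan-2-yl on the saturated ring carbon holds the number reached with 4-methylphenyl, so the step stays within the scatter: a 1.5-fold lower number from compound 3 to compound 4 (0.18 log units; within the scatter). This position therefore accepts a five-membered aromatic ring with 1 hetero atom in place of a six-membered aromatic ring of carbon only, with no measurable change in this assay. Against the 4-chlorophenyl group the same exchange is beyond the scatter, a 7.8-fold lower number from compound 1 to compound 4 (0.89 log units; beyond the scatter), so compounds 3 and 4 both stand at lower numbers than compound 1.

Open, as far as these compounds go, is whether a saturated ring such as cyclohexyl, or an open chain such as n-butyl, would serve at this carbon as the aromatic rings do. Also open, from the compounds shown here alone, is the configuration at this carbon in compounds 3 and 4, both drawn without one, a question raised by the earlier pair: the fact that one of compounds 1 and 2 is drawn with a defined configuration and the other without, at the place where they differ.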